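A Longer Chain on the Best Compound So Far

This account rests on a few compounds, and the source may have more. Where it says the series, first, only, none or still open, it means among the compounds named here.

Three compounds measured in a functional assay (trachea) with Cavia porcellus as the target (on this read-out lower numbers stand for stronger inhibition and higher numbers for weaker inhibition), so far
compound 1 `CCn1nc(-c2cccnc2)c2ccccc2c1=O` gives 1320 nM
compound 2 `CCn1nc(-n2cncn2)c2ccccc2c1=O` gives 15800 nM
compound 3 `CCn1nc(-c2cncs2)c2ccccc2c1=O` gives 562 nM

Compound 3 gives the lowest number of the three. The measurements show a 2.3-fold lower number from compound 1 to compound 3 (0.37 log units; beyond the scatter) as a modest change and a 28-fold lower number from compound 2 to compound 3 (1.45 log units; beyond the scatter) as a large one. Compound 4 `CC(C)Cn1nc(-c2cncs2)c2ccccc2c1=O` keeps the 1,3-thiazol-5-yl group and differs by isopropyl in place of methyl on a saturated chain carbon bound to an aromatic nitrogen in one place only: isopropyl in place of methyl on a saturated chain carbon bound to an aromatic nitrogen, so that ethyl becomes isobutyl.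

Also large is a 12-fold higher number from compound 1 to compound 2 (1.08 log units; beyond the scatter) but all three measured steps swap a group on an aromatic carbon, and none alters this chain. They show how far the numbers in this assay can move but give neither size nor direction for this change. No shift beyond the scatter is therefore expected, and a 1.1-fold lower number from compound 3 to compound 4 (0.05 log units; within the scatter) is the expected step as a best guess rather than a trend. Compound 4 is estimated at 500 nM within an expected range of 120 nM to 2000 nM for now.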

Compound 4, half-maximal inhibitory concentration: 2400 nM
Compound 4: middle estimate off by 4.8-fold (0.68 log units), on the low side, and the stated range ends below it.
By their numbers in this assay, from the lowest: compound 3; then compounds 1 and 4 (each within the scatter of the next); then compound 2.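

Until now, only the group on an aromatic carbon had been changed. This result shows that the chain on the aromatic nitrogen also affects the read-out: with the 1,3-thiazol-5-yl group held fixed, going from ethyl to isobutyl gives a 4.3-fold higher number from compound 3 to compound 4 (0.63 log units; beyond the scatter) in this assay and so weakens inhibition by a modest step. Nothing at hand explains why the number rises. A single chain change cannot show whether the branching or the extra carbons matter, nor how a straight propyl chain or a chain ending in an amine would read out. Going by these compounds, it also remains open whether isobutyl in place of ethyl would have a similar effect on compound 1, which carries pyridin-3-yl instead of 1,3-thiazol-5-yl.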